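Swapping cyclopropyl for phenyl on a ring sulfonamide

The source may hold more compounds than are shown below. What is called first, only, known or untested is meant among the compounds shown, and "the series" means these compounds.

Compound 1 `CC(C)CC1n2cncc2CN(CC2CC2)S1(=O)=O` was tested in an assay on cells for inhibition of cytochrome P450 11B1, mitochondrial (Homo sapiens) (a lower number here means a stronger inhibitor, a higher number a weaker inhibitor), where compound 1 gives 122 nM. Going by the values given here, that is the higher of the two numbers measured so far: the other compound, compound 2 `N#Cc1ccc(C2C(=O)N(Cc3ccccc3)Cc3cncn32)cc1`, is built on a different core, and in this assay compound 2 gives 2 nM, a gap that lies beyond the scatter. Compound 3 `CC(C)CC1n2cncc2CN(Cc2ccccc2)S1(=O)=O` keeps the core of compound 1 and differs in one place: phenyl in place of cyclopropyl on a saturated chain carbon bound to a sulfonamide nitrogen in a ring, so the cyclopropylmethyl group becomes a benzyl group. Among the compounds with values here, no measured pair shows this exact change on this core, so the size of the step cannot be read from earlier data. Since a lower number means a stronger inhibitor, a modest step downward is expected for compound 3, close to the edge of the scatter, expressed as a 2.2-fold lower number from compound 1 to compound 3 (0.35 log units; beyond the scatter). For compound 3 the estimate is 55 nM, with a range from 15 nM to 200 nM.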

Compound 3, half-maximal inhibitory concentration: 103 nM
Beside the measured number, compound 3's estimate is 1.9-fold (0.27 log units) below it; the measured number falls inside the stated range.
By their numbers in this assay, from the lowest: compound 2; then compounds 3 and 1 (each within the scatter of the next).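

In this assay the change from cyclopropyl to phenyl on the saturated chain carbon bound to the ring sulfonamide nitrogen gives a 1.2-fold lower number from compound 1 to compound 3 (0.07 log units; within the scatter) and so shows that, on this core, the two groups cannot be told apart at this position. The swap replaces a three-membered non-aromatic ring with a six-membered aromatic ring, going from 3 to 6 heavy atoms, yet the reading stays within the usual variation between repeat measurements. No available evidence bears on why the two groups read alike.

The compounds shown leave open whether an amine or a carboxylic acid in place of the phenyl would shift the number beyond the scatter. They also leave open what a longer chain between the sulfonamide nitrogen and the phenyl would do.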